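Methoxy addition on the aryl ketone ring of the chalcone

The source may hold more compounds than are shown below. What is called first, only, known or untested is meant among the compounds shown, and "the series" means these compounds.

Compound 1 `COc1ccc(-c2cc(/C=C/C(=O)c3ccc(N)cc3)[nH]n2)cc1` gives 61% in a functional assay on CCRF-CEM cells (Homo sapiens) for cytotoxicity, read by sulforhodamine B assay, with a stated time of 48 h, tested at 1 uM; on this read-out higher numbers stand for a weaker effect at the one concentration tested and lower numbers for a stronger effect. Within the data shown here, compound 3 `COc1ccc(-c2cc(/C=C/C(=O)c3ccc(N)cc3)[nH]n2)cc1OC` carries the change methoxy in place of hydrogen on an aromatic carbon and gives 68%; the step of a number 7 percentage points higher from compound 1 to compound 3 (within the scatter) is the only measured instance of this change. Compound 2 `COc1ccc(C(=O)/C=C/c2cc(-c3cc(OC)c(OC)c(OC)c3)n[nH]2)cc1OC` gives 39%, the lowest of the three numbers, and its gaps to compound 1 and compound 3 lie beyond the scatter. The difference between the core of compound 2 and the core of compound 1 is not broken down here.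

Compound 4 `COc1cc(C(=O)/C=C/c2cc(-c3cc(OC)c(OC)c(OC)c3)n[nH]2)cc(OC)c1OC` is not yet measured. It differs from compound 2 by methoxy in place of hydrogen on an aromatic carbon, the same kind of change as that from compound 1 to compound 3, though the place differs: in compound 4 the entering methoxy is also meta to a methoxy group, which is not so in compound 3. For compound 4 the expected step is a number 3 percentage points higher from compound 2 to compound 4 (within the scatter), resting on the within-scatter step a number 7 percentage points higher from compound 1 to compound 3 (within the scatter) as the one measured case. Compound 4 is estimated at 42%, between 25% and 60%.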

Compound 4, a percentage reported as activity, at one concentration (the size of the read-out at that concentration, not a potency): 67%
Estimate against measurement, compound 4: 25 percentage points below; the measured number lies above the stated range.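

The methoxy-for-hydrogen change does not carry over from one core to another with a constant size in this assay: the same change on two cores in this assay, a number 7 percentage points higher (within the scatter) from compound 1 to compound 3 and a number 28 percentage points higher (beyond the scatter) from compound 2 to compound 4, 21 percentage points apart, beyond the scatter of two such steps On the core of compound 2, the step of a number 28 percentage points higher from compound 2 to compound 4 (beyond the scatter) marks a weaker effect at the one concentration tested, so the earlier step is a poor guide to the size of the change on this core. Among these compounds, with only two pairs, and with the entering methoxy in compound 4 meta to a methoxy group, which is not so in compound 3, the data do not show whether the core or the place accounts for the gap, and they give no general rule for the series.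

Open, on these data alone, is whether the weaker effect of compound 4 is specific to methoxy or would also appear with a hydroxyl or a chlorine at the same place on the core of compound 2. Also open, as far as these compounds go, is how the same methoxy change would behave at that place on the core of compound 1.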